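Cyclohexyl to 2-fluorophenyl: what to expect for compound 4

The compounds below may be only part of what the source reports. "The series", "measured", "known", "first", "only" and "open" are said of these compounds alone.

Compound 1 `CC(C)(C)OC[C@@H](O)C(=O)N1[C@H](C(=O)NCc2cc(Cl)ccc2-n2cnnn2)C[C@@H]2C[C@@H]21`: 4.5 10^-6 cm/s
Compound 2 `CC1(C[C@@H](O)C(=O)N2N=CC[C@H]2C(=O)NCc2cc(Cl)ccc2-n2cnnn2)CC1`: 9.5 10^-6 cm/s
Compound 3 `O=C(NCc1cc(Cl)ccc1-n1cnnn1)[C@@H]1C[C@@H]2C[C@@H]2N1C(=O)[C@H](O)C1CCCCC1`: 16 10^-6 cm/s

In an ADME assay on Caco-2 cells (Homo sapiens) for permeability, read by LC-MS, in the apical to basolateral direction, with a stated time of 60 min, at pH 6.5 (a higher number here means that the compound crosses the layer faster, a lower number that the compound crosses the layer more slowly), compound 3 stands at 16 10^-6 cm/s, within the usual scatter of compound 2. Compound 4 `O=C(NCc1cc(Cl)ccc1-n1cnnn1)[C@@H]1C[C@@H]2C[C@@H]2N1C(=O)[C@H](O)c1ccccc1F` alters compound 3 in one place: 2-fluorophenyl in place of cyclohexyl on a saturated chain carbon bound to a carbonyl carbon and an oxygen on a saturated carbon. Going by the values given here, one measured step touches that same place, a 3.6-fold higher number from compound 1 to compound 3 (0.55 log units; beyond the scatter), when cyclohexyl replaced (tert-butoxy)methyl. Among the compounds with values here, it shows that this place can matter, but no measured compound carries 2-fluorophenyl there, so the direction remains uncertain. A small downward move, probably not beyond the scatter, is expected, written as a 1.5-fold lower number from compound 3 to compound 4 (0.16 log units; within the scatter). Compound 4 is estimated at 11 10^-6 cm/s, with an expected range from 4.5 10^-6 cm/s to 24 10^-6 cm/s.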

Compound 4, apparent permeability: 16 10^-6 cm/s
Compound 4: the middle estimate sits 1.5-fold (0.16 log units) below what was measured, within the range that was stated.
By their numbers in this assay, from the lowest: compound 1; then compounds 2, 3 and 4 (each within the scatter of the next).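

In this assay, the aromatic 2-fluorophenyl ring replaces the saturated cyclohexyl ring with no change at the digits printed from compound 3 to compound 4 (within the scatter), so at this place the two rings read alike. Against the open (tert-butoxy)methyl chain, 2-fluorophenyl gives a 3.6-fold higher number from compound 1 to compound 4 (0.55 log units; beyond the scatter), a step that matches the one cyclohexyl gave, a 3.6-fold higher number from compound 1 to compound 3 (0.55 log units; beyond the scatter). Nothing measured here says why the two rings read alike.

The compounds shown leave open what the fluorine itself contributes. They also leave open how a plain phenyl, or a ring carrying an amine or a carboxylic acid, would read at this place.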